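The source may hold more compounds than are shown below. What is called first, only, known or untested is meant among the compounds shown, and "the series" means these compounds.

Compound 2 `CC1=C(C(=O)CC(C)C)C(c2ccoc2)NC(=O)N1` and compound 1 `CC1=C(C(=O)C2CC2)C(c2ccoc2)NC(=O)N1` share a core and differ only by isobutyl in place of cyclopropyl on a carbonyl carbon. In an assay on membranes from HeLa cells for displacement of a labelled ligand from adenosine receptor A3 (Homo sapiens), read by scintillation counting, with a stated time of 180 min, tested at 1 uM (on this read-out lower numbers stand for less inhibition and higher numbers for more inhibition at the one concentration tested (going by the name of the read-out)), compound 2 gives 18%, and compound 1 gives 16%; the step of a number 2 percentage points higher from compound 1 to compound 2 (within the scatter) lies within the scatter, so the two numbers cannot be told apart. Compound 3 `CCNC(=O)C1=C(C)NC(=O)NC1c1ccoc1` is unmeasured; from compound 2 it differs by ethylamino in place of isobutyl on a carbonyl carbon. Among the compounds with values here, no measured step swaps an alkyl for an amino group on this carbonyl carbon, so no direct precedent exists. Given that the only step measured here stayed flat, the step of a number 3 percentage points lower from compound 2 to compound 3 (within the scatter) is expected to stay within the scatter. Compound 3 is therefore estimated at 15%, with a range from 0% to 38%.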

Compound 3, a percentage reported as inhibition, at one concentration (the size of the read-out at that concentration, not a potency): 1%
For compound 3 the middle estimate is 14 percentage points above the measured one; the measured number falls inside the stated range.
By their numbers in this assay, from the lowest: compound 3; then compounds 1 and 2 (each within the scatter of the next).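

Within the data shown here, on this carbonyl carbon, ethylamino is the first change that registers in this assay: in place of isobutyl it gives a number 17 percentage points lower from compound 2 to compound 3 (beyond the scatter), and in place of cyclopropyl it gives a number 15 percentage points lower from compound 1 to compound 3 (beyond the scatter). The two alkyl groups remain within the scatter of each other, while the ethylamino compound stands apart from both, so the number at this position does respond to the group on the carbonyl carbon. Nothing available explains the fall.

On these data alone, whether the fall follows the amide hydrogen or the nitrogen itself stays open. Dimethylamino or ethoxy on this carbonyl carbon would bear on that question.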